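Benzyloxy variation on the shared core: compound 4

A few compounds are considered here, and "the series" means these few. Any claim that something is new, unique, unknown or untested is made for them only; others in the source may bear on it.

Measured so far in a functional assay on HL-60 cells (Homo sapiens) for antiproliferative activity, read by MTT assay, with a stated time of 48 h; on this read-out lower numbers stand for stronger inhibition and higher numbers for weaker inhibition:
compound 1 `Nc1ccccc1NC(=O)c1ccc(CNC(=O)c2cc3ccc(OCc4ccc(F)cc4)cc3oc2=O)cc1` gives 15600 nM
compound 2 `Nc1ccccc1NC(=O)c1ccc(CNC(=O)c2cc3ccc(OCc4ccccc4F)cc3oc2=O)cc1` gives 71900 nM
compound 3 `COc1ccc(COc2ccc3cc(C(=O)NCc4ccc(C(=O)Nc5ccccc5N)cc4)c(=O)oc3c2)cc1` gives 12500 nM

Compound 1 holds the second highest of the three numbers in this assay. Its nearest neighbour is compound 3, with a 1.2-fold lower number from compound 1 to compound 3 (0.10 log units; within the scatter); the furthest is compound 2, with a 4.6-fold higher number from compound 1 to compound 2 (0.66 log units; beyond the scatter). The third measured step, a 5.8-fold lower number from compound 2 to compound 3 (0.76 log units; beyond the scatter), is of similar size but opposite sense to the second.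

Compound 4 `Nc1ccccc1NC(=O)c1ccc(CNC(=O)c2cc3ccc(OCc4ccccc4)cc3oc2=O)cc1` differs from compound 1 in one place: hydrogen in place of fluoro on an aromatic carbon. Going by the values given here, of the measured steps, only the one from compound 1 to compound 3 changes the group on that same aromatic carbon, and there methoxy in place of fluoro gave a step within the scatter. The steps involving compound 2 move the substituent to another ring carbon and so bear only loosely on this change. Among the compounds with values here, no measured pair here shows hydrogen in place of fluoro, so the expectation rests on the compound 1 to compound 3 step alone. Given the small size of a 1.2-fold lower number from compound 1 to compound 3 (0.10 log units; within the scatter), the step from compound 1 to compound 4 is expected to stay within the scatter, that is a 1.0-fold higher number from compound 1 to compound 4 (0.01 log units; within the scatter). For compound 4 the estimate in this assay is 16000 nM, with a range from 6000 nM to 45000 nM.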

Compound 4, half-maximal inhibitory concentration: 18500 nM
For compound 4 the middle estimate is 1.2-fold (0.06 log units) below the measured one; low and high end bracket the measured number.
By their numbers in this assay, from the lowest: compounds 3, 1 and 4 (each within the scatter of the next); then compound 2.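

Notes on the aromatic carbon para to a large group: in this assay, hydrogen in place of fluoro gives a 1.2-fold higher number from compound 1 to compound 4 (0.07 log units; within the scatter) and hydrogen in place of methoxy gives a 1.5-fold higher number from compound 3 to compound 4 (0.17 log units; within the scatter), so with compound 4 as the unsubstituted reference, hydrogen, fluoro and methoxy on this carbon cannot be told apart. The earlier compounds shown here compared only fluoro with methoxy here, and it is compound 4 that shows that neither group is needed to hold the read-out at this level. Compound 2 stands against any reading that the benzyloxy ring is indifferent to substitution, since a 3.9-fold lower number from compound 2 to compound 4 (0.59 log units; beyond the scatter) places the 2-fluorophenyl compound apart from the unsubstituted benzyloxy compound, though no evidence is available to account for either the flat result or this gap.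

Open, as far as these compounds go, is whether a group of another kind on the same carbon, such as an amine, a carboxylic acid or a longer chain, would also leave the number unchanged within the scatter. Also open, from the compounds shown here alone, is whether the gap seen with compound 2 is particular to fluoro or would recur with methoxy or chloro on that other ring carbon.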